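Notes: trifluoromethoxy in place of fluoro on compound 2

The compounds below may be only part of what the source reports. "The series", "measured", "known", "first", "only" and "open" are said of these compounds alone.

Measured so far:
- compound 1 `O=C(C[C@]1(O)CC[C@@H](Cc2ccc(OC(F)(F)F)cc2)CC1)Nc1ccc2[nH]c(=O)oc2c1` gives 53.4%
- compound 2 `O[C@]1(Cc2cc(-c3cn[nH]c3)on2)CC[C@H](Cc2ccc(F)cc2)CC1` gives 78%

In an ADME assay on the whole organism (strain Sprague-Dawley) for pharmacokinetics, with Rattus norvegicus as the target, using cassette dosing, at a dose of 1 mg/kg by the oral route (a higher number here means that a larger share of the oral dose reaches the circulation, a lower number that a smaller share of the oral dose reaches the circulation), compound 2 gives 78% and stands highest of the two numbers. Compound 1 lies lower, by a gap beyond the usual scatter.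

The next compound to be measured is compound 3 `O[C@]1(Cc2cc(-c3cn[nH]c3)on2)CC[C@H](Cc2ccc(OC(F)(F)F)cc2)CC1` with the core of compound 2 unchanged. It carries trifluoromethoxy in place of fluoro on an aromatic carbon and the site is para to a large group.

Within the data shown here, no pair of measured compounds differs in one place only, so the size of this step has no direct precedent. Among the measured compounds shown here, the only guide is compound 1, which carries the same trifluoromethoxy group on a different core and gives 53.4% in this assay as its reading. On that thin basis, a downward step of moderate size, near the edge of the scatter, is expected.

The estimated change is a number 12 percentage points lower from compound 2 to compound 3 (beyond the scatter) and this remains an expectation only. Compound 3 is expected at 66% (estimated range 42% to 88%) until it is measured.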

Compound 3, oral bioavailability: 121%
Compound 3: the middle estimate sits 55 percentage points below what was measured; the measured number lies above the stated range.
By their numbers in this assay, from the lowest: compound 1; then compound 2; then compound 3.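

In this assay, among these compounds, trifluoromethoxy in place of fluoro on an aromatic carbon, para to a large group, gives a number 43 percentage points higher from compound 2 to compound 3 (beyond the scatter), the first single-change step, and it shows that this position takes the larger group with no loss in this read-out on this core. Compound 3 gives 121%, more than the whole of the oral dose, so this reading cannot be taken literally as a share and the step is safer read for its direction than for its exact size. Nothing measured here bears on why the number moves this way.

The step is a single pair on a single core, so it remains open whether the same exchange gives a similar rise on the core of compound 1, for which no fluoro partner is shown. Also open, on these data alone, is how other groups at the same place would read in this assay, for instance a methoxy, a chloro, a nitrile, an amine or a carboxylic acid, and whether the rise follows the trifluoromethoxy group alone.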